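A few compounds are considered here, and "the series" means these few. Any claim that something is new, unique, unknown or untested is made for them only; others in the source may bear on it.

Measured so far:
Compound 1 `CC(=O)NC[C@H]1CN(c2ccc(-c3ccc(/C=N/N4CC[S+]([O-])CC4)c(O)c3)c(F)c2)C(=O)O1`: in an ADME assay on isolated protein for inhibition of Amine oxidase [flavin-containing] A (Homo sapiens), read by luminescence, with stated times of 15 min and 60 min, tested at 30 uM (on this read-out lower numbers stand for less inhibition and higher numbers for more inhibition at the one concentration tested (going by the name of the read-out)), compound 1 gives 88%.
Compound 2 `CC(=O)NC[C@H]1CN(c2ccc(-c3ccc(/C=N/N4CCSCC4)c(O)c3)c(F)c2)C(=O)O1`: in this assay compound 2 gives 62%.

Compound 2 stands lowest of the two numbers; its nearest neighbour is compound 1, whose number is higher by a step stated as beyond the scatter.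

Among the compounds with values here, the one step available joins these two: a number 26 percentage points lower from compound 1 to compound 2 (beyond the scatter). That step replaces the oxidised sulfur ring of compound 1 with the plain thiomorpholine ring of compound 2 and lowers inhibition by a modest amount.

Compound 3 `CC(=O)NC[C@H]1CN(c2ccc(-c3ccc(/C=N/N4CCS(=O)(=O)CC4)c(O)c3)c(F)c2)C(=O)O1` is not yet measured. Its difference from compound 2 is 1,1-dioxothiomorpholin-4-yl in place of thiomorpholin-4-yl on a double-bonded nitrogen. Within the data shown here, the change runs in the opposite sense to the one measured step, again at the sulfur of the same ring, and with one oxygen more than compound 1 carries. The measured step from compound 1 to compound 2 therefore bears on it directly, and a rise of similar size back toward the number of compound 1 is expected, with the extra oxygen an untested further move.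

Compound 3 is expected to give 82% in this assay, within 62% to 96%, which means an expected step of a number 20 percentage points higher from compound 2 to compound 3 (beyond the scatter).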

Compound 3, a percentage reported as inhibition, at one concentration (the size of the read-out at that concentration, not a potency): 67%
For compound 3 the middle estimate is 15 percentage points above the measured one; the range from low to high includes it.
By their numbers in this assay, from the lowest: compounds 2 and 3 (each within the scatter of the next); then compound 1.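

In this assay, 1,1-dioxothiomorpholin-4-yl in place of thiomorpholin-4-yl on a double-bonded nitrogen gives a number 5 percentage points higher from compound 2 to compound 3 (within the scatter) and so does not separate these two rings, although the singly oxidised sulfur ring of compound 1 differs from the thiomorpholine ring beyond the scatter. A second step, a number 21 percentage points lower from compound 1 to compound 3 (beyond the scatter), sets compound 1 apart from the fully oxidised ring as well, so the number does not follow the count of oxygens on the ring sulfur across these three compounds: the plain ring and the ring with two oxygens cannot be told apart, and only the ring with one oxygen stands clear of both. Nothing available explains why compound 1 stands apart.

Still open, from the compounds shown here alone, is whether this difference belongs to the sulfur oxide itself or would also appear with another ring on the same nitrogen, such as morpholine, piperazine or a ring carrying a carbonyl. Going by these compounds, these percentages come from one concentration, so the order of the three compounds over a wider range of concentrations also remains open.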